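This account rests on a few compounds, and the source may have more. Where it says the series, first, only, none or still open, it means among the compounds named here.

Measured so far in a functional assay on HT-29 cells (Homo sapiens) for inhibition, read by sulforhodamine B assay, with a stated time of 72 h; a higher number here means a weaker inhibitor, a lower number a stronger inhibitor:
- compound 1 `C=CC1C(=O)N(c2cc(OC)c(OC)c(OC)c2)C1c1ccc(SC)cc1`: 113 nM
- compound 2 `COc1ccc(C2C(Oc3ccccc3)C(=O)N2c2cc(OC)c(OC)c(OC)c2)cc1`: 52 nM

Compound 2, at 52 nM, holds the lower of the two numbers. The gap to compound 1, at 113 nM, lies beyond the usual scatter, though two values give only a thin base for ranking.

Next in the series is compound 3 `C=CC1C(=O)N(c2cc(OC)c(OC)c(OC)c2)C1c1ccc(OC)cc1`, not yet measured. Compared with compound 2, it has vinyl in place of phenoxy on a saturated ring carbon. For the measured compounds named here, no measured pair shows this change on its own, so its size in this assay remains unknown. Going by the values given here, the only other measured compound bearing vinyl is compound 1, at 113 nM, which gives a weak hint towards a higher number but cannot separate the effect of vinyl from the other structural differences.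

No clear direction is therefore expected, and the estimated step, a 1.0-fold lower number from compound 2 to compound 3 (0.02 log units; within the scatter), stays within the scatter. The uncertainty remains wide on both sides.

For compound 3 the expected value is 50 nM, with an estimated range of 10 nM to 200 nM.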

Compound 3, half-maximal inhibitory concentration: 10 nM
Estimate against measurement, compound 3: 5.0-fold (0.70 log units) above, and the stated range covers the measured number.
By their numbers in this assay, from the lowest: compound 3; then compound 2; then compound 1.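

In this assay, the saturated ring carbon two ring bonds from the ring nitrogen does not need phenoxy for a low number: vinyl in place of phenoxy gives a 5.2-fold lower number from compound 2 to compound 3 (0.72 log units; beyond the scatter), so the aromatic ring of phenoxy can be lost at this position without any loss in this read-out. For the compounds shown here, the aromatic substituent also matters with vinyl held constant, as methoxy in place of methylsulfanyl on an aromatic carbon gives an 11-fold lower number from compound 1 to compound 3 (1.05 log units; beyond the scatter), a step beyond the scatter that isolates this change for the first time. Nothing available on these compounds accounts for either step.

As far as these compounds go, each change rests on a single pair, so it remains open whether vinyl itself is favourable or whether other groups on the saturated ring carbon, such as ethyl, hydroxyl, an amine or a longer chain, would give similar numbers. From the compounds shown here alone, it also remains open whether the methoxy over methylsulfanyl step carries over when phenoxy rather than vinyl sits on that carbon.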